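The compounds below may be only part of what the source reports. "The series", "measured", "known", "first", "only" and "open" are said of these compounds alone.

Measured compounds:
Compound 1 `CC1=CC[C@H](C(C)C)c2cc(C)c(OC(=O)c3ccc([N+](=O)[O-])cc3)cc21` — in a functional assay on K562 cells (Homo sapiens) for antiproliferative activity, read by sulforhodamine B assay, with a stated time of 48 h, tested at 50 uM (on this read-out lower numbers stand for less inhibition and higher numbers for more inhibition at the one concentration tested (going by the name of the read-out)), compound 1 gives 89%.
Compound 2 `COc1cccc(C(=O)Oc2cc3c(C)ccc(C(C)C)c3cc2C)c1` — in this assay compound 2 gives 14.2%.
Compound 3 `CC1=CC[C@H](C(C)C)c2cc(C)c(OC(=O)c3ccc(C(F)(F)F)cc3)cc21` — in this assay compound 3 gives 9%.

Compound 1 stands highest of the three numbers in this assay; the nearest is compound 2 and the furthest is compound 3, both beyond the scatter. Within the data shown here, the only single-place step among the measured compounds is a number 80 percentage points lower from compound 1 to compound 3 (beyond the scatter), a large fall on swapping the substituent on the aromatic ring of the ester.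

Compound 4 `CC1=CC[C@H](C(C)C)c2cc(C)c(OC(=O)c3cccc(C)c3)cc21` is not yet measured. It differs from compound 1 as follows: 3-methylphenyl in place of 4-nitrophenyl on a carbonyl carbon. Among the measured compounds shown here, no measured pair shows exactly this exchange. The step from compound 1 to compound 3 is the one that bears on it: removing the nitro group in favour of another substituent cost most of the inhibition. For the measured compounds named here, compound 2, which carries a 3-methoxyphenyl ester on a different core, also sits low, though no step to it is computed. A large downward step in this assay is therefore expected for compound 4, a number 74 percentage points lower from compound 1 to compound 4 (beyond the scatter). The estimate for compound 4 is 15%, within 3% to 40%.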

Compound 4, a percentage reported as inhibition, at one concentration (the size of the read-out at that concentration, not a potency): "not active" (no number reported)
No number was reported for compound 4, and the estimate cannot be compared.
By their numbers in this assay, from the lowest: compounds 3 and 2 (each within the scatter of the next); then compound 1.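

Compound 4 carries only the label "not active" in this assay, with no number, so no step from compound 1 to compound 4 can be read, and nothing measured here accounts for that result. The compounds shown leave open how far compound 4 lies from compounds 2 and 3, and whether the high value of compound 1 depends on its 4-nitrophenyl group.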